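The source may hold more compounds than are shown below. What is called first, only, known or untested is meant among the compounds shown, and "the series" means these compounds.

In a functional assay on K562 cells (Homo sapiens) for inhibition, read by sulforhodamine B assay, with a stated time of 48 h, tested at 50 uM (a lower number here means less inhibition of growth, a higher number more inhibition of growth at the concentration tested), compound 1 `Cc1ccc(F)c(C(=O)c2ccc3nc(NC(=O)C(F)(F)F)cn3c2)c1` gives 92.6%. Compound 3 `Cn1cc(C(=O)c2ccc3nc(NC(=O)C(F)(F)F)cn3c2)c2ccccc21` gives 95.5%, which lies within the scatter of the value for compound 1, so these two form the upper pair of the three numbers. Compound 2 `Cc1ccc(C(=O)c2ccc3nc(NC(=O)C(F)(F)F)cn3c2)cc1F` gives 52.2%, well apart from compound 1.

The next compound, compound 4 `O=C(c1ccc2nc(NC(=O)C(F)(F)F)cn2c1)c1cc(C(F)(F)F)ccc1F`, has not yet been measured. It differs from compound 1 by trifluoromethyl in place of methyl on an aromatic carbon, with trifluoromethyl in place of methyl on an aromatic carbon, para to a fluoro group.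

No measured pair makes this exchange, so its size is not shown directly. Among the measured compounds shown here, the one step that bears on it is a number 40.4 percentage points lower from compound 1 to compound 2 (beyond the scatter), with 3-fluoro-4-methylphenyl in place of 2-fluoro-5-methylphenyl on a carbonyl carbon. That large step shows that this assay can respond strongly to a change in this phenyl group. It involves a different substitution pattern, however, whereas compound 4 keeps the pattern of compound 1 and changes only the group at one place. A fall smaller than that step is therefore expected, although a larger loss cannot be excluded.

The expected change is a number 10.6 percentage points lower from compound 1 to compound 4 (beyond the scatter). For compound 4 the estimated value is 82%, with an expected range from 55% to 98%.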

Compound 4, percent growth inhibition at one concentration: 88%
The estimate for compound 4 lay 6 percentage points below the measured number, within the range that was stated.
By their numbers in this assay, from the lowest: compound 2; then compounds 4, 1 and 3 (each within the scatter of the next).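

In this assay the exchange of methyl for trifluoromethyl gives a number 4.6 percentage points lower from compound 1 to compound 4 (within the scatter) and so shows that this place, on an aromatic carbon para to a fluoro group, accepts the larger group, with four heavy atoms standing where one stood. Among the compounds shown here, the earlier compounds showed only that a different substitution pattern on the phenyl group can carry a large cost, as in a number 40.4 percentage points lower from compound 1 to compound 2 (beyond the scatter) and the new step shows that no such cost appears when the pattern of compound 1 is kept and only this one group changes. Nothing at hand gives a reason why the number holds across this exchange.

The compounds shown leave open whether this place would accept a group of another kind, such as an amine, a carboxylic acid or a longer chain, as it accepts trifluoromethyl. They also leave open whether trifluoromethyl would give a similar result on the substitution pattern of compound 2, and whether the numbers would stay this close at other concentrations.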